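A few compounds are considered here, and "the series" means these few. Any claim that something is new, unique, unknown or untested is made for them only; others in the source may bear on it.

Compound 1 `C(=N/Nc1nc2ccccc2nc1Cc1ccccc1)\c1ccccc1`: 320000 nM
Compound 2 `Oc1ccc(/C=N/Nc2nc3ccccc3nc2Cc2ccccc2)cc1`: 7900000 nM
Compound 3 `C/C(=N\Nc1nc2ccccc2nc1Cc1ccccc1)c1ccc(C)cc1`: 740000 nM

All three share one core and were tested in an assay on isolated protein for inhibition of Amine oxidase [flavin-containing] B (Homo sapiens), read by spectrophotometry; a lower number here means a stronger inhibitor, a higher number a weaker inhibitor. Compound 2 gives the highest number of the three, so it is the weakest inhibitor here; compound 3 and compound 1 both give lower numbers, beyond the scatter. Among the compounds with values here, the one measured step that changes a single place is a 25-fold higher number from compound 1 to compound 2 (1.39 log units; beyond the scatter), where a hydroxy group was added to the outer ring and the number rose sharply.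

Compound 4 `Cc1ccsc1/C=N/Nc1nc2ccccc2nc1Cc1ccccc1` has not yet been measured. Compared with compound 2, (3-methylthiophen-2-yl in place of 4-hydroxyphenyl on a carbon with a double bond to nitrogen). This change removes the hydroxy group that set compound 2 apart from compound 1, and at the same time swaps the whole ring it sat on for a smaller ring that carries a sulfur and a methyl group. Within the data shown here, no measured compound holds such a ring, so the size of the effect of the ring swap itself is unknown.

Because of a 25-fold higher number from compound 1 to compound 2 (1.39 log units; beyond the scatter), taking the hydroxy away again is expected to bring the number back down, roughly to the level of compound 1, giving an expected step of a 20-fold lower number from compound 2 to compound 4 (1.30 log units; beyond the scatter) in this assay. Compound 4 is therefore estimated at 400000 nM, within a range from 100000 nM to 2000000 nM.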

Compound 4, half-maximal inhibitory concentration: 860000 nM
The estimate for compound 4 lay 2.2-fold (0.33 log units) below the measured number; the measured number falls inside the stated range.
By their numbers in this assay, from the lowest: compound 1; then compounds 3 and 4 (each within the scatter of the next); then compound 2.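

In this assay, a carbon with a double bond to nitrogen accepts a five-membered aromatic ring carrying sulfur and a methyl group: replacing 4-hydroxyphenyl with 3-methylthiophen-2-yl gives a 9.2-fold lower number from compound 2 to compound 4 (0.96 log units; beyond the scatter) and so recovers much of the ground lost with compound 2. The ring swap is not neutral, however, since replacing the plain phenyl with the same 3-methylthiophen-2-yl group gives a 2.7-fold higher number from compound 1 to compound 4 (0.43 log units; beyond the scatter), which leaves compound 1 as the better of this pair and shows that the new ring does not fully match phenyl at this position. The step from compound 2 removes the hydroxy group and changes the ring at once, so its size cannot be divided between those two changes, and no supporting measurement explains either step.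

The compounds shown leave open how much of the rise from phenyl to 3-methylthiophen-2-yl belongs to the methyl group and how much to the sulfur-containing ring itself, a question that the same ring without its methyl group could address. They also leave open how this position would respond to a methoxy group or an amine on the outer ring in place of the hydroxy group.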